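Chloro on the Pendant Phenyl Across Two Cores

This account rests on a few compounds, and the source may have more. Where it says the series, first, only, none or still open, it means among the compounds named here.

Measured in a functional assay on HCT-116 cells (Homo sapiens) for cytotoxicity, read by sulforhodamine B assay, with a stated time of 48 h; on this read-out higher numbers stand for weaker inhibition and lower numbers for stronger inhibition:
compound 1 `O=S(=O)(c1ccccc1)c1cnc2cc(-c3ccccc3)nn2c1-c1ccccc1` gives 1.27 ug/mL
compound 2 `O=S(=O)(c1ccccc1)c1cnc2cc(-c3ccc(Cl)cc3)nn2c1-c1ccccc1` gives 1.64 ug/mL
compound 3 `O=S(=O)(c1ccccc1)c1cnc2ncnn2c1-c1ccccc1` gives 1.97 ug/mL

Compound 2 differs from compound 1 by chloro in place of hydrogen on an aromatic carbon, and in this assay this gave a 1.3-fold higher number from compound 1 to compound 2 (0.11 log units; within the scatter). Compound 3 carries a different core; the difference between the two cores is not broken down here. Compound 4, `O=S(=O)(c1ccccc1)c1cnc2ncnn2c1-c1ccc(Cl)cc1`, differs from compound 3 by chloro in place of hydrogen on an aromatic carbon, the same change as between compound 1 and compound 2, at the same kind of place. Because the earlier step of a 1.3-fold higher number from compound 1 to compound 2 (0.11 log units; within the scatter) stayed within the scatter, compound 4 is expected to land close to compound 3, with an estimated 1.2-fold higher number from compound 3 to compound 4 (0.09 log units; within the scatter). The estimate for compound 4 in this assay is 2.4 ug/mL, expected between 1.2 ug/mL and 4.8 ug/mL.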

Compound 4, half-maximal inhibitory concentration: 2.15 ug/mL
The estimate for compound 4 lay 1.1-fold (0.05 log units) above the measured number; low and high end bracket the measured number.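

In this assay the change from phenyl to 4-chlorophenyl gives a 1.1-fold higher number from compound 3 to compound 4 (0.04 log units; within the scatter). Set beside the earlier step, the two cores agree: the same change on two cores in this assay, a 1.3-fold higher number (0.11 log units; within the scatter) from compound 1 to compound 2 and a 1.1-fold higher number (0.04 log units; within the scatter) from compound 3 to compound 4, 1.2-fold (0.07 log units) apart, within the scatter of two such steps. This shows only that adding chloro left no readable mark on either core; a step this small cannot show that a real effect carries from one core to another, and two cores say nothing about a third.

The compounds shown leave open whether a different group in the same place, such as an amine or a carboxylic acid, would move the number beyond the scatter. They also leave open whether such a step would then turn out the same size on both cores.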